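The compounds below may be only part of what the source reports. "The series", "measured", "known", "first", "only" and "open" are said of these compounds alone.

Working notes on the series. Three compounds of the shared core carry numbers in a functional assay on HEK293 cells for activation of melanin-concentrating hormone receptor 1 (Homo sapiens), read by inositol phosphate accumulation; a lower number here means that less compound is needed, a higher number that more compound is needed for the effect. Compound 1 `CCCc1cc(N)c2cc(NC(=O)c3ccc(-c4ccc(Cl)cc4)cc3)ccc2n1` gives 75 nM. Compound 2 `CCCc1ccc(/C=C/C(=O)Nc2ccc3nc(CCC)cc(N)c3c2)cc1` gives 3600 nM. Compound 3 `CC(C)c1cc(N)c2cc(NC(=O)/C=C/c3ccc(C(F)(F)F)cc3)ccc2n1` gives 160 nM. Among these three numbers compound 3 holds the second highest: its nearest neighbour is compound 1, whose number is lower by a margin beyond the usual scatter, and the furthest is compound 2, whose number is higher by a wide margin. Among the measured compounds shown here, no pair of the measured compounds differs in a single place, so no isolated step can be read from them.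

Compound 4 `Cc1cc(N)c2cc(NC(=O)/C=C/c3ccc(C(F)(F)F)cc3)ccc2n1` is the next candidate. Set against compound 3 the difference is methyl in place of isopropyl on an aromatic carbon. For the measured compounds named here, no measured pair isolates this change; the group next to the ring nitrogen is propyl in compound 1 and compound 2 and isopropyl in compound 3, and the rest of each molecule varies at the same time, so the measured numbers give no clean reading on it. The step from compound 3 to compound 4 is therefore expected to be small, a 1.6-fold higher number from compound 3 to compound 4 (0.19 log units; within the scatter), a slight move toward a higher number that need not exceed the scatter. Compound 4 is expected to give about 250 nM in this assay, with a range from 100 nM to 600 nM.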

Compound 4, half-maximal effective concentration: 140 nM
For compound 4 the middle estimate is 1.8-fold (0.25 log units) above the measured one, and the stated range covers the measured number.
By their numbers in this assay, from the lowest: compounds 1, 4 and 3 (each within the scatter of the next, the first and the last beyond it); then compound 2.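

In this assay the series now has its first isolated step, a 1.1-fold lower number from compound 3 to compound 4 (0.06 log units; within the scatter), with methyl in place of isopropyl on the aromatic carbon next to the ring nitrogen. With the rest of the molecule held fixed, the two groups cannot be told apart in this setting, so at this position a group of 3 heavy atoms and one of 1 heavy atom read alike, and the size of the group here has no visible bearing on the number across this single change. No supporting measurement bears on why the step is this small.

Going by these compounds, the reading rests on one pair, so it remains open whether it carries over to propyl, the group at this position in compound 1 and compound 2, or to the different amide portions of those two compounds. Also open, on these data alone, is how a much larger or different group at this position, such as a hydrogen, a cyclohexyl ring, a primary amine or a longer chain like hexyl, would read against methyl and isopropyl.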